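Ring amine at the pyridine in place of dimethylamino

This account rests on a few compounds, and the source may have more. Where it says the series, first, only, none or still open, it means among the compounds named here.

Measured so far in a functional assay on CHO-K1 cells for antagonist activity at transient receptor potential cation channel subfamily V member 1 (Homo sapiens), read by FLIPR; a higher number here means a weaker inhibitor, a lower number a stronger inhibitor:
- compound 1, `CC1CCC(Nc2nc(C(F)(F)F)ccc2CNC(=O)C(C)c2ccc(NS(C)(=O)=O)c(F)c2)CC1`, gives 27.2 nM
- compound 2, `CC(C(=O)NCc1ccc(C(F)(F)F)nc1NCc1ccccc1)c1ccc(NS(C)(=O)=O)c(F)c1`, gives 15.8 nM
- compound 3, `CC(C(=O)NCc1ccc(C(F)(F)F)nc1N(C)C)c1ccc(NS(C)(=O)=O)c(F)c1`, gives 19.1 nM

Compound 3 stands second highest of the three numbers, but its gaps to both neighbours are within the scatter, so no order among the three can be claimed. The next compound, compound 4 `CC(C(=O)NCc1ccc(C(F)(F)F)nc1N1CCCCC1C)c1ccc(NS(C)(=O)=O)c(F)c1`, differs from compound 3 in one place: 2-methylpiperidin-1-yl in place of dimethylamino on an aromatic carbon.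

Among the compounds with values here, two measured steps bear on this change, since both alter the same amine on the shared core. The step of a 1.4-fold lower number from compound 1 to compound 3 (0.15 log units; within the scatter) and the step of a 1.2-fold higher number from compound 2 to compound 3 (0.08 log units; within the scatter) both stayed within the scatter, even though a bulky ring-bearing amine was exchanged for the small dimethylamino group. The reverse move now, from dimethylamino to the ring-bearing 2-methylpiperidin-1-yl, is therefore expected to change this assay little, with no direction beyond the scatter, and the expected step is a 1.2-fold lower number from compound 3 to compound 4 (0.08 log units; within the scatter). Compound 4 is thus estimated at 16 nM in this assay, with a range from 5 nM to 50 nM.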

Compound 4, inhibition constant: 2.9 nM
Beside the measured number, compound 4's estimate is 5.5-fold (0.74 log units) above it; measured number below the stated range.
By their numbers in this assay, from the lowest: compound 4; then compounds 2, 3 and 1 (each within the scatter of the next).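

In this assay, within the data shown here, swapping one amine for another at this place on the shared core had so far produced no readable change, but 2-methylpiperidin-1-yl gives a 6.6-fold lower number from compound 3 to compound 4 (0.82 log units; beyond the scatter) and also a 5.4-fold lower number from compound 2 to compound 4 (0.74 log units; beyond the scatter) and a 9.4-fold lower number from compound 1 to compound 4 (0.97 log units; beyond the scatter) so this position does respond to the choice of amine. Size alone does not account for the pattern, since the large benzylamino of compound 2 and (4-methylcyclohexyl)amino of compound 1 stay within the scatter of the small dimethylamino of compound 3, and the absence of a hydrogen-bond donor alone does not either, since dimethylamino in compound 3 also has none; among these four compounds, only the amine whose nitrogen sits in a ring stands apart. No measurement shown here explains why this ring behaves differently.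

The compounds shown leave open whether the gain belongs to the ring itself or to its methyl group, a question that plain piperidin-1-yl, with the same ring and no methyl, would address. A smaller pyrrolidin-1-yl ring or a morpholin-4-yl ring, with oxygen in the ring, would show how much this ring can change while keeping the gain.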